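Sulfonylurea chalcones: cytotoxicity toward brine shrimp, compound 3

The source may hold more compounds than are shown below. What is called first, only, known or untested is meant among the compounds shown, and "the series" means these compounds.

Compound 1 `COc1ccc(/C=C/C(=O)c2ccccc2NC(=O)NS(=O)(=O)c2ccc(C)cc2)cc1OC` and compound 2 `Cc1ccc(S(=O)(=O)NC(=O)Nc2ccccc2C(=O)/C=C/C=C/c2ccccc2)cc1` share the core and differ only in the aryl group on the chain. In an ADME assay on the whole organism for cytotoxicity, with Artemia salina as the target, with a stated time of 24 h (a lower number here means that less compound is needed, a higher number that more compound is needed for the effect), compound 1 gives 12.9 ug/mL and compound 2 gives 18.2 ug/mL; the step of a 1.4-fold higher number from compound 1 to compound 2 (0.15 log units; within the scatter) exchanges the aryl group at the same place as the change now considered. Among the compounds with values here, compound 2 stands at the highest of the two numbers so far, though its gap to compound 1 is within the scatter. Compound 3 `Cc1ccc(S(=O)(=O)NC(=O)Nc2ccccc2C(=O)/C=C/c2ccncc2)cc1` carries the change (pyridin-4-yl in place of 2-phenylethenyl on a double-bonded chain carbon bound to a double-bonded chain carbon). Within the data shown here, the only step that bears on this change is a 1.4-fold higher number from compound 1 to compound 2 (0.15 log units; within the scatter), which was within the scatter, so no step beyond the scatter is expected for compound 3 in this assay, in either direction. For compound 3 the expected step is a 1.1-fold lower number from compound 2 to compound 3 (0.06 log units; within the scatter). Compound 3 is estimated at 16 ug/mL in this assay, with a range from 7 ug/mL to 36 ug/mL.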

Compound 3, concentration for half-maximal effect: 16.8 ug/mL
Compound 3: middle estimate off by 1.1-fold (0.02 log units), on the low side; the measured number falls inside the stated range.
By their numbers in this assay, from the lowest: compounds 1, 3 and 2 (each within the scatter of the next).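

In this assay, the place on a double-bonded chain carbon bound to a double-bonded chain carbon now also holds an aromatic ring with a hetero atom, and the numbers stay together: the change to pyridin-4-yl gives a 1.1-fold lower number from compound 2 to compound 3 (0.03 log units; within the scatter) and a 1.3-fold higher number from compound 1 to compound 3 (0.11 log units; within the scatter). Neither exchange, which brings in a ring nitrogen and a hydrogen-bond acceptor, moves the number beyond the scatter, so all three groups read alike at this place. No measurement at hand accounts for this flat result.

As far as these compounds go, all three compounds carry an uncharged aromatic group at this place, so it remains open whether an amine, a carboxylic acid or a saturated alkyl chain there would give a step beyond the scatter. From the compounds shown here alone, whether the shared core would respond to changes elsewhere also remains open.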